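Aryl swap on the thiosemicarbazone: compound 3 to compound 4

The compounds below may be only part of what the source reports. "The series", "measured", "known", "first", "only" and "open" are said of these compounds alone.

Compound 3 `CC1=CC[C@@H]([C@@](C)(O)CCCC(C)(C)NC(=S)N/N=C\c2ccc([N+](=O)[O-])cc2)CC1` gives 9560 nM in a functional assay on K562 cells (Homo sapiens) for cytotoxicity, read by sulforhodamine B assay; a lower number here means a stronger inhibitor of growth, a higher number a weaker inhibitor of growth. Among the three measured compounds this is the second highest number; compound 1 `CC1=CC[C@@H]([C@@](C)(O)CCCC(C)(C)NC(=S)N/N=C\c2ccc(C)cc2)CC1` gives 7950 nM, and compound 2 `CC1=CC[C@@H]([C@@](C)(O)CCCC(C)(C)NC(=S)N/N=C\c2ccc(O)cc2)CC1` gives 31100 nM. Within this trio the aryl substituent on the carbon double-bonded to nitrogen is the only variable: a 1.2-fold higher number from compound 1 to compound 3 (0.08 log units; within the scatter), a 3.9-fold higher number from compound 1 to compound 2 (0.59 log units; beyond the scatter), and a 3.3-fold lower number from compound 2 to compound 3 (0.51 log units; beyond the scatter). The number thus moves within the scatter when methyl and nitro are exchanged and beyond it only when hydroxy is involved.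

Compound 4 `CC1=CC[C@@H]([C@@](C)(O)CCCC(C)(C)NC(=S)N/N=C\c2ccccc2Cl)CC1` differs from compound 3 in that (2-chlorophenyl in place of 4-nitrophenyl on a carbon with a double bond to nitrogen). Within the data shown here, no measured step introduces chlorine on the aryl group, and none changes the point of attachment of the substituent, so the change has no direct precedent. Among the measured compounds shown here, the steps that bear on it are those on the same carbon, a 1.2-fold higher number from compound 1 to compound 3 (0.08 log units; within the scatter) and a 3.3-fold lower number from compound 2 to compound 3 (0.51 log units; beyond the scatter), which together suggest that exchanging one substituent for another leaves the number roughly unchanged unless hydroxy enters. A step of a 1.1-fold lower number from compound 3 to compound 4 (0.05 log units; within the scatter) is therefore expected in this assay, none beyond the scatter. Compound 4 is estimated at 8500 nM, with a range from 3000 nM to 25000 nM.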

Compound 4, concentration for total growth inhibition: 4110 nM
For compound 4 the middle estimate is 2.1-fold (0.32 log units) above the measured one; measured number inside the range.
By their numbers in this assay, from the lowest: compounds 4, 1 and 3 (each within the scatter of the next, the first and the last beyond it); then compound 2.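

In this assay, 2-chlorophenyl in place of 4-nitrophenyl on a carbon with a double bond to nitrogen gives a 2.3-fold lower number from compound 3 to compound 4 (0.37 log units; beyond the scatter), so an exchange without hydroxy can also move the number beyond the scatter, which the exchange of methyl and nitro did not show. Among these compounds, replacing 4-hydroxyphenyl gives a 7.6-fold lower number from compound 2 to compound 4 (0.88 log units; beyond the scatter), the largest step so far, whereas replacing 4-methylphenyl gives a 1.9-fold lower number from compound 1 to compound 4 (0.29 log units; within the scatter), which leaves compound 4 and compound 1 level, with neither to be called the stronger inhibitor of growth. No accompanying measurement bears on what lies behind these steps.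

From the compounds shown here alone, compound 4 changes both the substituent and its point of attachment at once, and whether chlorine or the new attachment carries the step stays open. Also open, going by these compounds, is how the number responds at this carbon to an aryl group bearing an amine, a carboxylic acid or a methoxy group, and whether the order of compounds 4, 1, 3 and 2 holds in other cell lines.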